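The source may report more compounds than this note shows. Statements on the series, on what has been measured and on what is new or still open speak of the compounds shown alone.

Compound 1, `Cc1ccc(NC(=O)Nc2cccc(NC(=O)c3ccccn3)c2)cc1`, in a functional assay on A549 cells (Homo sapiens) for antiproliferative activity, read by MTT assay, with a stated time of 48 h (a lower number here means a stronger inhibitor, a higher number a weaker inhibitor), compound 1 gives 20 nM.
Compound 2, `O=C(Nc1cccc(NC(=O)c2ccccn2)c1)NC1CCCCC1`, in this assay compound 2 gives 6260 nM.
Compound 3, `CCN1CCN(C(=S)SCC(=O)Nc2cccc(NC(=O)c3ccccn3)c2)CC1`, in this assay compound 3 gives 3720 nM.

Among these three, compound 3 holds the second highest number. Its nearest neighbour is compound 2, whose number is only a little higher, a gap that lies within the usual scatter of repeated measurements, so the two cannot be told apart. Compound 1 lies far below it, a gap well beyond the scatter.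

Compound 4, `O=C(CSC(=S)N1CCN(c2ncccn2)CC1)Nc1cccc(NC(=O)c2ccccn2)c1`, arises from compound 3 by a single change: pyrimidin-2-yl in place of ethyl on an amine nitrogen in a ring. Among the measured compounds shown here, only one measured step exists for comparison, a 310-fold higher number from compound 1 to compound 2 (2.50 log units; beyond the scatter), and it concerns a different place, an amide-type nitrogen, and a different kind of swap, one ring for another. It therefore says little about a change on the ring amine nitrogen. For the measured compounds named here, no measured pair varies that position. With no guide, the expectation for compound 4 is a number close to that of compound 3, with a wide band of uncertainty. Compound 4 is expected to give 3500 nM, somewhere between 900 nM and 14000 nM, which would be a step of a 1.1-fold lower number from compound 3 to compound 4 (0.03 log units; within the scatter), not beyond the scatter.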

Compound 4, half-maximal inhibitory concentration: 40 nM
The estimate for compound 4 lay 88-fold (1.94 log units) above the measured number, and the stated range ends above it.
By their numbers in this assay, from the lowest: compounds 1 and 4 (each within the scatter of the next); then compounds 3 and 2 (each within the scatter of the next).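

In this assay, the group on the amine nitrogen in a ring turns out to matter a great deal: pyrimidin-2-yl in place of ethyl gives a 93-fold lower number from compound 3 to compound 4 (1.97 log units; beyond the scatter). Among the compounds shown here, the only earlier step concerned an amide-type nitrogen, so this is the first measured sign that a single change at this second place can also shift the number by a large amount. The swap brings in several things at once, namely more heavy atoms, a six-membered aromatic ring, and 2 hydrogen-bond acceptors, and nothing measured here says which of them matters.

From the compounds shown here alone, it remains open whether the ring alone is enough or whether its nitrogens are needed: phenyl on the same nitrogen would carry a six-membered aromatic ring with no hetero atoms, and pyridin-2-yl would carry a single ring nitrogen. A longer chain such as butyl in place of ethyl would show whether added size without any ring moves the number at all.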